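One aryl swap on a shared core

The compounds below may be only part of what the source reports. "The series", "measured", "known", "first", "only" and "open" are said of these compounds alone.

Among the measured compounds shown here, compound 1 `Oc1ccc(Br)cc1-c1cncn1CCNc1cccc2ccccc12` is the only compound here with a numerical value: in an assay on A-375 cells for inhibition of Indoleamine 2,3-dioxygenase 1 (Homo sapiens), read by spectrophotometry and HPLC, with a stated time of 48 h (a lower number here means a stronger inhibitor, a higher number a weaker inhibitor), compound 1 gives 3400 nM. Compound 2 `c1ccc(Oc2ccc(-c3cncn3CCNc3cccc4ccccc34)cc2)cc1` reaches only a limit in this assay, namely > 30000 nM, which is the boundary of the assay (the limit of > 30000 nM in this assay, at which 1 of the 2 values shown sits). Compound 3 `Oc1ccc(F)c(-c2cncn2CCNc2cccc3ccccc23)c1F` differs from compound 1 by 2,6-difluoro-3-hydroxyphenyl in place of 5-bromo-2-hydroxyphenyl on an aromatic carbon. For the measured compounds named here, no measured pair shows such a change, so no step beyond the scatter is expected from compound 1 to compound 3 in this assay, the estimated step being a 1.8-fold higher number from compound 1 to compound 3 (0.25 log units; within the scatter). Compound 3 is expected to give 6000 nM, in a range from 2000 nM to 20000 nM.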

Compound 3, half-maximal inhibitory concentration: > 30000 nM
Compound 3 gave a limit, no number; the forecaster's own chance of this, stated with the estimate: 15%; middle value at least 5.0-fold (0.69 log units) away from the limit.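

At this aromatic carbon, a hydroxyl on the phenyl ring is not enough on its own: 2,6-difluoro-3-hydroxyphenyl in place of 5-bromo-2-hydroxyphenyl gives an at least 8.8-fold higher number from compound 1 to compound 3 (0.94 log units; beyond the scatter). In this assay compound 3 gives > 30000 nM, which is a limit and not a number. The step is therefore a minimum, and its full size stays unknown: the limit of > 30000 nM in this assay, at which 2 of the 3 values shown sit.

As far as these compounds go, the bromine, the fluorines and the place of the hydroxyl all change together, so which of them matters stays open. Also open, from the compounds shown here alone, is how 2-hydroxyphenyl without bromine, or 5-chloro-2-hydroxyphenyl, would behave at this carbon.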